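This account rests on a few compounds, and the source may have more. Where it says the series, first, only, none or still open, it means among the compounds named here.

Of the compounds shown here, three of a shared core have been measured for their effect on liver-derived cancer cells. Compound 1 `FC(F)(F)c1ccc(C2CC(c3ccccc3)=NN2c2ccc(-c3ccccc3)nn2)cc1` gives 10000 nM in a functional assay on HepG2 cells (Homo sapiens) for antiproliferative activity, read by MTT assay, with a stated time of 24 h; on this read-out higher numbers stand for weaker inhibition and lower numbers for stronger inhibition. Compound 2 `Clc1ccc(C2=NN(c3ccc(-c4ccccc4)nn3)C(c3ccccc3)C2)cc1` gives 8750 nM in this assay, and compound 3 `FC(F)(F)c1ccc(C2CC(c3ccc(Cl)cc3)=NN2c2ccc(-c3ccccc3)nn2)cc1` gives 8330 nM. The two steps that lead to compound 3 are both small: a 1.2-fold lower number from compound 1 to compound 3 (0.08 log units; within the scatter) and a 1.1-fold lower number from compound 2 to compound 3 (0.02 log units; within the scatter), so all three numbers sit within the scatter of one another and compound 3 cannot be set apart from the others.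

Compound 4 `COc1cc(C2CC(c3ccc(Cl)cc3)=NN2c2ccc(-c3ccccc3)nn2)cc(OC)c1OC` has not yet been measured. It differs from compound 3 in one place: 3,4,5-trimethoxyphenyl in place of 4-(trifluoromethyl)phenyl on a saturated ring carbon. Going by the values given here, no measured step exchanges one aryl group for another; the nearest is the step from compound 2 to compound 3, which concerns the trifluoromethyl group that now leaves and stayed within the scatter. With every measured change in this assay small, the exchange is expected to give at most a modest shift, a 1.2-fold lower number from compound 3 to compound 4 (0.08 log units; within the scatter). Compound 4 is therefore estimated at 7000 nM in this assay, with a range from 2500 nM to 20000 nM.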

Compound 4, half-maximal inhibitory concentration: > 100000 nM
Compound 4: only a limit was reported; the forecaster's own chance of this, stated with the estimate: 25%; at least 14-fold (1.15 log units) between middle value and limit.
By their numbers in this assay, from the lowest: compounds 3, 2 and 1 (each within the scatter of the next). At a limit, above all of these: compound 4.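

In this assay, going by these compounds alone, the saturated ring carbon next to the ring nitrogen is the first place on the shared core where a change reaches beyond the scatter: 3,4,5-trimethoxyphenyl in place of 4-(trifluoromethyl)phenyl gives an at least 12-fold higher number from compound 3 to compound 4 (1.07 log units; beyond the scatter), and the same group in place of phenyl gives an at least 11-fold higher number from compound 2 to compound 4 (1.05 log units; beyond the scatter). The two groups it replaces stand within the scatter of each other, with a 1.1-fold lower number from compound 2 to compound 3 (0.02 log units; within the scatter), so this carbon bears those two aryl groups alike but not the trimethoxy-substituted one. The value of compound 4 is a limit of the assay and not a number: the limit of > 100000 nM in this assay, at which 1 of the 4 values shown sits.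

The compounds shown leave open whether a single methoxy group on this phenyl ring would already bring such a step or whether the full 3,4,5-trimethoxyphenyl group is needed. They also leave open how an amine or a carboxylic acid on this ring would fare.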